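A few compounds are considered here, and "the series" means these few. Any claim that something is new, unique, unknown or untested is made for them only; others in the source may bear on it.

Measured so far:
- compound 1, `CNC(=O)[C@@H](c1ccccc1)N1CCn2c(CC3CC3)nc(Cl)c2[C@@H]1CCc1ccc(C(F)(F)F)cc1`: 1430 nM
- compound 2, `CNC(=O)[C@@H](c1ccccc1)N1CCn2c(COC)nc(Cl)c2[C@@H]1CCc1ccc(C(F)(F)F)cc1`: 1650 nM
- compound 3, `CCc1nc(C(C)C)c2n1CCN([C@@H](C(=O)NC)c1ccccc1)C2CCc1ccc(C(F)(F)F)cc1`: 10000 nM

All three were tested in a functional assay on CHO cells for antagonist activity at Orexin/Hypocretin receptor type 1 (Homo sapiens), read by FLIPR and calcium flux; on this read-out higher numbers stand for weaker inhibition and lower numbers for stronger inhibition. Compound 3 stands highest of the three numbers, that is, it is the weakest inhibitor of this set: compound 2 is nearest to it and compound 1 is furthest from it, both gaps beyond the scatter.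

Compound 4, `C=Cc1nc(CC)n2c1C(CCc1ccc(C(F)(F)F)cc1)N([C@@H](C(=O)NC)c1ccccc1)CC2`, is the unmeasured neighbour of compound 3. The change is vinyl in place of isopropyl on an aromatic carbon.

Within the data shown here, the only measured step, a 1.2-fold higher number from compound 1 to compound 2 (0.06 log units; within the scatter), concerns a different place on the shared core and is within the scatter, so it says nothing about swapping groups on the aromatic carbon. Among the measured compounds shown here, no measured pair shows the isopropyl-to-vinyl exchange itself. Compounds 1 and 2 carry chlorine on that aromatic carbon and give lower numbers than compound 3, but they differ from compound 3 in more than one place, so that comparison cannot be read as a clean step.

For the measured compounds named here, with no directly bearing step, compound 4 is expected to land near compound 3, with a step of a 1.7-fold lower number from compound 3 to compound 4 (0.22 log units; within the scatter), and the estimate for compound 4 is 6000 nM, within 1500 nM to 15000 nM.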

Compound 4, half-maximal inhibitory concentration: 150 nM
Estimate against measurement, compound 4: 40-fold (1.60 log units) above; the measured number lies below the stated range.
By their numbers in this assay, from the lowest: compound 4; then compounds 1 and 2 (each within the scatter of the next); then compound 3.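

In this assay, among these compounds, the exchange of isopropyl for vinyl on this aromatic carbon gives a 67-fold lower number from compound 3 to compound 4 (1.82 log units; beyond the scatter) and is the first clean step at this position, which shows that the number here depends strongly on the group the carbon carries. The edit is small on paper: 3 heavy atoms leave and 2 heavy atoms enter, no ring is involved on either side, neither group has hydrogen-bond donors or acceptors, and the one new feature is a double bond outside aromatic rings. No measurement of any property of these groups accompanies the result, so the size of the step stays unexplained.

A single pair cannot separate the effect of the double bond from that of losing a carbon, and a methyl group or an ethynyl group on the same carbon would be needed to tell these apart. From the compounds shown here alone, it also remains open how a nitrile or an amine would behave at this position, and whether vinyl gives a similar step when the ethyl group on the same ring is replaced by a longer chain.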